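This account rests on a few compounds, and the source may have more. Where it says the series, first, only, none or still open, it means among the compounds named here.

In a functional assay on A549 cells (Homo sapiens) for antiproliferative activity, read by MTT assay, with a stated time of 48 h (a higher number here means a weaker inhibitor, a lower number a stronger inhibitor), compound 2 `O=C(/C=C/c1ccc(C(F)(F)F)cc1)Nc1nnc(-c2ccccc2)s1` gives 1.78 ug/mL and compound 1 `Cc1ccc(-c2nnc(NC(=O)/C=C/c3ccc(C(F)(F)F)cc3)s2)cc1` gives 1.61 ug/mL, so the two stand level within the scatter. Compound 3 `O=C(/C=C/c1ccccc1)Nc1nnc(-c2ccccc2)s1` has hydrogen in place of trifluoromethyl on an aromatic carbon. Among the measured compounds shown here, the only measured step, a 1.1-fold higher number from compound 1 to compound 2 (0.04 log units; within the scatter), also puts hydrogen on an aromatic carbon, but in place of methyl and at a different place, so it is only a loose guide. No clear step beyond the scatter is therefore expected in this assay, perhaps a slightly higher number. The expected change is a 1.3-fold higher number from compound 2 to compound 3 (0.11 log units; within the scatter). For compound 3 the estimated value is 2.3 ug/mL, with an expected range of 1 ug/mL to 5.5 ug/mL.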

Compound 3, half-maximal inhibitory concentration: 1.75 ug/mL
For compound 3 the middle estimate is 1.3-fold (0.12 log units) above the measured one, and the stated range covers the measured number.
By their numbers in this assay, from the lowest: compounds 1, 3 and 2 (each within the scatter of the next).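

In this assay, replacing trifluoromethyl with hydrogen on the six-membered aromatic ring, para to a large group, gives a 1.0-fold lower number from compound 2 to compound 3 (0.01 log units; within the scatter) and leaves the two compounds level. Compound 3 thus shows that, in this assay and on this core, the trifluoromethyl group can give way to a plain hydrogen with no step beyond the scatter. No measured evidence accounts for this result.

On these data alone, whether an amine, a carboxylic acid or a methoxy group at this position would also stand level remains open. Also open, as far as these compounds go, is whether the same replacement would behave alike in compound 1.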